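Swapping a basic amine tail for a plain butyl chain

The compounds below may be only part of what the source reports. "The series", "measured", "known", "first", "only" and "open" are said of these compounds alone.

Compound 1 `CN(C)CCCNc1nc(NCc2ccco2)c2ccccc2n1` carries a three-carbon chain ending in a dimethylamino group on the shared core; in a functional assay on HT-29 cells (Homo sapiens) for cytotoxicity, read by MTT assay, with a stated time of 2 days, tested at 10 uM (on this read-out lower numbers stand for less inhibition and higher numbers for more inhibition at the one concentration tested (going by the name of the read-out)), compound 1 gives "not determined" (no result reported), so no number stands for it. Two related compounds with an arylpiperazine on the chain were measured: in this assay compound 2 `Cc1cccc(N2CCN(CCCNc3nc(NCc4ccco4)c4ccccc4n3)CC2)c1C` gives 94%, and compound 3 `Cc1cccc(N2CCN(CCCCNc3nc(NCc4ccco4)c4ccccc4n3)CC2)c1C` gives 94.2%. These two values lie within the usual scatter of each other. Compound 4 `CCCCNc1nc(NCc2ccco2)c2ccccc2n1` differs from compound 1 by methyl in place of dimethylamino on a saturated chain carbon, three bonds along the chain from a nitrogen on an aromatic ring. Since compound 1 has no number, no step can be computed, and the direction of the change in this assay cannot be read from the measurements shown. Compound 4 is expected to reach about 55%, with a range from 15% to 90%.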

Compound 4, a percentage reported as inhibition, at one concentration (the size of the read-out at that concentration, not a potency): 92.3%
Estimate against measurement, compound 4: 37.3 percentage points below; measured number outside the range, above it.
By their numbers in this assay, from the lowest: compounds 4, 2 and 3 (each within the scatter of the next).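

In this assay, for the compounds shown here, compound 1 gives "not determined" (no result reported) and so no step to compound 4 can be read. On these data alone, what changing 3-(dimethylamino)propyl to butyl does to this read-out stays open. Nothing shown offers an explanation for the result of compound 4.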